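Adding a methyl ester to a polyene oxo-acid agonist

A few compounds are considered here, and "the series" means these few. Any claim that something is new, unique, unknown or untested is made for them only; others in the source may bear on it.

Of the compounds shown here, two have been measured in a functional assay on cells for agonist activity at Oxoeicosanoid receptor 1 (Homo sapiens), read by beta-arrestin recruitment; on this read-out higher numbers stand for an effect only at larger amounts of compound and lower numbers for an effect already at smaller amounts. Compound 1, with the structure `CCCCC/C=C\C/C=C\C/C=C\C=C\C(=O)CCCC(=O)OC`, gives 1540 nM in this assay. Compound 2, with the structure `CC/C=C\C/C=C\C/C=C\C/C=C\C=C\C(=O)CCCC(=O)O`, gives 380 nM in this assay, the lower of the two numbers, with compound 1 standing beyond the usual scatter above it. The two compounds are not single-change partners, so these values alone do not isolate any one structural feature.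

Compound 3, with the structure `CC/C=C\C/C=C\C/C=C\C/C=C\C=C\C(=O)CCCC(=O)OC`, has not yet been measured. It differs from compound 2 by methyl in place of hydrogen on an oxygen next to a carbonyl group, so the free acid becomes its methyl ester. Since compound 1, which also carries a methyl ester, gives 1540 nM, the expectation is a step toward a higher number, estimated as a 3.9-fold higher number from compound 2 to compound 3 (0.60 log units; beyond the scatter). Compound 3 is therefore expected to give about 1500 nM in this assay, with a range from 500 nM to 5000 nM.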

Compound 3, half-maximal effective concentration: 2080 nM
Compound 3: middle estimate off by 1.4-fold (0.14 log units), on the low side; the measured number falls inside the stated range.
By their numbers in this assay, from the lowest: compound 2; then compounds 1 and 3 (each within the scatter of the next).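

Going by these compounds alone, with the rest of the structure held the same, placing methyl in place of hydrogen on an oxygen next to a carbonyl group, so that carboxy becomes methoxycarbonyl, gives in this assay a 5.5-fold higher number from compound 2 to compound 3 (0.74 log units; beyond the scatter), which isolates this one change for the first time. Among the methyl esters, but-1-en-1-yl in place of butyl gives a 1.4-fold higher number from compound 1 to compound 3 (0.13 log units; within the scatter), so this difference in the chain does not separate the two esters on this read-out. Nothing measured here explains either step.

Going by these compounds, whether an ethyl ester or an amide at the same place would give numbers close to the free acid or close to the methyl ester remains open. So does the size of the butyl to but-1-en-1-yl change when a free carboxylic acid is present.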